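Aryl versus alkynyl groups on the shared nucleoside core

The compounds below may be only part of what the source reports. "The series", "measured", "known", "first", "only" and "open" are said of these compounds alone.

Compounds measured so far:
compound 1, `CCCCC#Cc1cc([C@@H]2O[C@H](CO)[C@@H](O)[C@H]2O)n2ncnc(N)c12` — 1000 nM
compound 2, `Nc1ncnn2c([C@@H]3O[C@H](CO)[C@@H](O)[C@H]3O)cc(C#Cc3cccs3)c12` — > 100000 nM

In a functional assay on LN-229 cells (Homo sapiens) for antiproliferative activity, with a stated time of 72 h (a lower number here means a stronger inhibitor, a higher number a weaker inhibitor), compound 1 gives 1000 nM. For compound 2 the result in this assay is a limit of the assay and not a number, > 100000 nM; it sits at the limit of > 100000 nM in this assay, at which 1 of the 2 values shown sits. Among the measured compounds shown here, the one measured step, an at least 100-fold higher number from compound 1 to compound 2 (2.00 log units; beyond the scatter), shows that thiophen-2-yl in place of butyl on a triple-bonded carbon weakens activity strongly.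

Compound 3, `COc1ccc(-c2cc([C@@H]3O[C@H](CO)[C@@H](O)[C@H]3O)n3ncnc(N)c23)cc1`, is not yet measured in this assay. Relative to compound 2 it carries 4-methoxyphenyl in place of 2-(thiophen-2-yl)ethynyl on an aromatic carbon. For the measured compounds named here, no measured step covers this change: the measured step concerns only the group on the triple-bonded carbon, and here the triple bond itself leaves together with the thiophen-2-yl, while a 4-methoxyphenyl enters directly on the aromatic carbon. Since compound 2 stands only at a limit, a step in either direction cannot be ruled out; a number is expected for compound 3 no stronger than that of compound 1. Compound 3 is estimated at 8000 nM with a range of 800 nM to 80000 nM, which means an expected step of an at least 12-fold lower number from compound 2 to compound 3 (1.09 log units; beyond the scatter).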

Compound 3, half-maximal inhibitory concentration: 40300 nM
Compound 3: middle estimate off by 5.0-fold (0.70 log units), on the low side; measured number inside the range.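

In this assay, a directly attached aryl group on this aromatic carbon still gives a measurable number, and 4-methoxyphenyl in place of 2-(thiophen-2-yl)ethynyl gives an at least 2.4-fold lower number from compound 2 to compound 3 (0.39 log units; beyond the scatter), so a triple bond at this place is not required for activity to be read. The hex-1-yn-1-yl group of compound 1 nevertheless stays ahead of the directly attached aryl group, with a 40-fold higher number from compound 1 to compound 3 (1.61 log units; beyond the scatter), which makes compound 1 the most potent of the three and shows that replacing the alkynyl group does not by itself recover its activity. Compound 2 stands at a limit of the assay, so the step from it gives only a bound on the size of the change and not a true size: the limit of > 100000 nM in this assay, at which 1 of the 3 values shown sits.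

Two changes are coupled in both new steps, the loss of the triple bond and the arrival of the aryl ring, and the compounds shown do not separate their contributions. Open as well are how a plain phenyl without the methoxy, or an amine or a longer chain on the triple-bonded carbon, would read against compound 1.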